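The source may report more compounds than this note shows. Statements on the series, on what has been measured and on what is new or still open speak of the compounds shown alone.

Compound 2 `CCCNC(=O)Nc1cccc2c1CN(C)CC2c1ccccc1` is one of three compounds that share a common core and have been tested in a functional assay on the whole organism for inhibition of sodium-dependent dopamine transporter (Mus musculus); a higher number here means that more compound is needed for the effect, a lower number that less compound is needed. In this assay compound 1 `CN1Cc2c(N)cccc2C(c2ccc(F)cc2)C1` gives 7.5 mg/kg. In this assay compound 3 `CCOC(=O)Nc1cccc2c1CN(C)CC2c1ccc(Cl)cc1` gives 21 mg/kg. Compound 2 stands apart from these two: in this assay compound 2 reaches only a limit of the assay, > 120 mg/kg, so no number is known for it. Within the data shown here, its standing among the values shown is marked by the limit of > 120 mg/kg in this assay, at which 1 of the 3 values shown sits, and it is the sole compound of the three without a measured value. Among the measured compounds shown here, no two of the measured compounds differ from each other in a single place, so no measured step can guide the next one.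

Compound 4 `CCCCNCCC(=O)Nc1cccc2c1CN(C)CC2c1ccccc1` has not yet been measured. It differs from compound 2 in one place: 2-(butylamino)ethyl in place of propylamino on a carbonyl carbon. Compound 2 sits at a limit, so the size of the step to compound 4 can only be guessed. In this assay compound 1 gives 7.5 mg/kg and compound 3 gives 21 mg/kg, which shows that other variations at this position of the core need far less compound. The expected step from compound 2 to compound 4 is an at least 2.4-fold lower number from compound 2 to compound 4 (0.38 log units; beyond the scatter), toward less compound needed. Compound 4 is estimated at 50 mg/kg in this assay, with a range from 12 mg/kg to 200 mg/kg.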

Compound 4, dose for half-maximal effect: > 60 mg/kg
Compound 4: no number, only a limit; the forecaster's own chance of this, stated with the estimate: 35%; middle value at least 1.2-fold (0.07 log units) away from the limit.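

Compound 2 and compound 4 each reach only a limit of the assay in this assay, so no step can be read between them. Going by these compounds, what stays open is whether 2-(butylamino)ethyl in place of propylamino on a carbonyl carbon changes the amount of compound needed at all, and in which direction.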